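This account rests on a few compounds, and the source may have more. Where it says the series, first, only, none or still open, it means among the compounds named here.

Measured compounds:
- compound 1 `CC(C)c1ccc(-c2nc(SCc3cn(CC(=O)NC(=O)Nc4ccccn4)nn3)nc(Nc3ccc(Cl)cc3)c2C#N)cc1` — 11200 nM in a functional assay on ECa-109 cells (Homo sapiens) for inhibition, read by MTT assay, with a stated time of 72 h; on this read-out lower numbers stand for stronger inhibition and higher numbers for weaker inhibition
- compound 2 `Cc1ccccc1Nc1nc(SCc2cn(CC(=O)NC(=O)Nc3ccccn3)nn2)nc(-c2ccc(C(C)C)cc2)c1C#N` — 7230 nM
- compound 3 `Cc1cccc(Nc2nc(SCc3cn(CC(=O)NC(=O)Nc4ccccn4)nn3)nc(-c3ccc(C(C)C)cc3)c2C#N)c1` — 7320 nM

Compound 3 gives 7320 nM in this assay, which cannot be told apart from compound 2 or compound 1, since every step among the three lies within the scatter: a 1.5-fold lower number from compound 1 to compound 2 (0.19 log units; within the scatter), a 1.5-fold lower number from compound 1 to compound 3 (0.18 log units; within the scatter), a 1.0-fold higher number from compound 2 to compound 3 (0.01 log units; within the scatter). The whole set so far occupies one narrow band.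

Compound 4 `CC(C)c1ccc(Nc2nc(SCc3cn(CC(=O)NC(=O)Nc4ccccn4)nn3)nc(-c3ccc(C(C)C)cc3)c2C#N)cc1` has not yet been measured. It differs from compound 3 in one place: 4-isopropylphenyl in place of 3-methylphenyl on a nitrogen on an aromatic ring. Among the measured compounds shown here, no measured pair covers this exact exchange; the three measured steps all exchange the group on the same nitrogen (chloro for methyl, or one methyl placement for another), and none moved the number beyond the scatter. The step to a 4-isopropylphenyl is a larger change in the group than any measured so far, so the range is set wider, but the expected direction is none beyond the scatter: the step is estimated as a 1.0-fold higher number from compound 3 to compound 4 (0.01 log units; within the scatter).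

Compound 4 is therefore expected to give about 7500 nM, with a range from 3000 nM to 20000 nM.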

Compound 4, half-maximal inhibitory concentration: 2490 nM
The estimate for compound 4 lay 3.0-fold (0.48 log units) above the measured number; the whole stated range lies above it.
By their numbers in this assay, from the lowest: compound 4; then compounds 2, 3 and 1 (each within the scatter of the next).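

In this assay, among the compounds shown here, the group on this nitrogen now registers for the first time: 4-isopropylphenyl gives a 2.9-fold lower number from compound 3 to compound 4 (0.47 log units; beyond the scatter) and a 2.9-fold lower number from compound 2 to compound 4 (0.46 log units; beyond the scatter) while exchanges among the 4-chlorophenyl, 2-methylphenyl and 3-methylphenyl groups had stayed within the scatter. Isopropyl in place of chloro on an aromatic carbon gives a 4.5-fold lower number from compound 1 to compound 4 (0.65 log units; beyond the scatter) and so shows that the number at this position depends on the group carried by the phenyl ring, with 9 heavy atoms in the entering 4-isopropylphenyl group tolerated and in fact favoured over the 7 of the 3-methylphenyl group. No measurement here bears on what underlies the step.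

Still open, going by these compounds, is whether the gain is particular to isopropyl or extends to a tert-butyl group or a longer chain such as n-butyl on the same ring. On these data alone, a methoxy group or an amine in that place also remains untested against the isopropyl result.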